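The source may hold more compounds than are shown below. What is called first, only, known or untested is meant among the compounds shown, and "the series" means these compounds.

Of the compounds shown here, three share one core and have been measured in an assay on isolated protein for inhibition of ubiquitin carboxyl-terminal hydrolase 7 (Homo sapiens), with stated times of 30 min and 2 h; a higher number here means a weaker inhibitor, a lower number a stronger inhibitor. Compound 1 `Cn1nc2c(=O)n(CC3(O)CCN(Cc4ccc(-c5n[nH]c(=O)o5)cc4Cl)CC3)cnc2c1-c1ccc(CN)cc1` gives 171 nM, compound 3 `Cn1nc2c(=O)n(CC3(O)CCN(Cc4ccc(-c5cnco5)cc4Cl)CC3)cnc2c1-c1ccc(CN)cc1` gives 71.6 nM, and compound 2 `Cn1nc2c(=O)n(CC3(O)CCN(Cc4ccc(-c5ccco5)cc4Cl)CC3)cnc2c1-c1ccc(CNC(=O)C(F)(F)F)cc1` gives 2060 nM. Compound 2 therefore stands highest of the three, so it is the weakest of the set; the nearest to it is compound 1, and the furthest is compound 3. Among the measured compounds shown here, the one measured step that differs in a single place, a 2.4-fold lower number from compound 1 to compound 3 (0.38 log units; beyond the scatter), concerns the five-membered aromatic ring on the aromatic carbon and does not touch the group at the benzylic amine.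

Compound 4 `Cn1nc2c(=O)n(CC3(O)CCN(Cc4ccc(-c5ccco5)cc4Cl)CC3)cnc2c1-c1ccc(CNC=O)cc1` differs from compound 2 by hydrogen in place of trifluoromethyl on a carbonyl carbon. For the measured compounds named here, no measured step bears directly on this change: compounds 1 and 3 carry a free aminomethyl group rather than a formylamino or trifluoromethylcarbonylamino group, and they also differ from compound 2 in the five-membered ring, so their values can only show that the two changes together move the number a long way, not what the amide cap alone does. Going by the values given here, with no step to lean on, compound 4 is expected to sit near compound 2, with perhaps a small gain, giving an estimated 1.5-fold lower number from compound 2 to compound 4 (0.17 log units; within the scatter) and an estimate of 1400 nM, within a range of 450 nM to 4500 nM.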

Compound 4, half-maximal inhibitory concentration: 20.9 nM
The estimate for compound 4 lay 67-fold (1.83 log units) above the measured number; the whole stated range lies above it.
By their numbers in this assay, from the lowest: compound 4; then compound 3; then compound 1; then compound 2.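

Exchanging trifluoromethyl for hydrogen on a carbonyl carbon bound to an amide-type nitrogen gives a 99-fold lower number from compound 2 to compound 4 (1.99 log units; beyond the scatter) in this assay. Among the compounds shown here, compound 2 and compound 4 differ nowhere else, so this pair isolates the amide cap from the five-membered ring that the earlier compounds left entangled with it, and it shows that this single place can move the number far more than the only earlier step, a 2.4-fold lower number from compound 1 to compound 3 (0.38 log units; beyond the scatter), which lies at the five-membered ring. The material shown offers no measurement that accounts for the size of this step.

Going by these compounds, with only formyl and (trifluoromethyl)carbonyl compared at this position, it remains open where an acetyl group, a longer acyl chain or a partly fluorinated cap such as difluoroacetyl would fall, and therefore whether the step follows from the fluorine atoms or from the size of the cap. It is also open how (formylamino)methyl compares with a free aminomethyl group on an otherwise identical compound, as no pair shown here separates those two groups.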